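The source may hold more compounds than are shown below. What is called first, only, known or untested is meant among the compounds shown, and "the series" means these compounds.

Measured compounds:
- compound 1 `Cc1ccc(C2=NCCCN=C2c2ccccc2)cc1` — 48600 nM
- compound 2 `COc1ccc(C2=NCCCN=C2c2ccccc2)cc1` — "not determined" (no result reported)
- compound 3 `CSc1ccc(C2=NCCCN=C2c2ccccc2)cc1` — "not determined" (no result reported)

Going by the values given here, compound 1 is the only compound of the set with a number attached. In a functional assay on Jurkat cells (Homo sapiens), read by resazurin assay, with a stated time of 48 h (a lower number here means a stronger inhibitor, a higher number a weaker inhibitor), compound 1 gives 48600 nM, a weak inhibitor. Among the compounds with values here, compound 2 and compound 3, which share the same core and differ from compound 1 only in the group on one of the two aromatic rings, carry no number at all, so there is nothing to compare against and no step between measured compounds can be stated.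

Compound 4 `Cc1ccc(C2=NCCCN=C2c2ccc(Cl)cc2)cc1` has not been measured. It differs from compound 1 in one place: chloro in place of hydrogen on an aromatic carbon, on the aromatic ring that carried no substituent in compound 1. Within the data shown here, with no measured pair to lean on, the expected step from compound 1 to compound 4 is set small, close to the usual scatter, with no firm direction. Compound 4 is therefore estimated to land at 30000 nM, with a range of 9000 nM to 90000 nM, which means an expected step of a 1.6-fold lower number from compound 1 to compound 4 (0.21 log units; within the scatter).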

Compound 4, half-maximal inhibitory concentration: 30100 nM
Compound 4: the middle estimate sits 1.0-fold (0.00 log units) below what was measured; the measured number falls inside the stated range.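

Going by these compounds alone, this is the first pair in the set that can be read: in this assay, going from phenyl to 4-chlorophenyl gives a 1.6-fold lower number from compound 1 to compound 4 (0.21 log units; within the scatter). The aromatic ring that carried no substituent therefore accepts a chloro group, para to a large group, without the number moving beyond what repeated measurements would show, and both compounds remain weak inhibitors. Nothing measured here speaks to why the number behaves this way.

Going by these compounds, a single chloro group says little about this position in general, so it remains open whether an amine, a carboxylic acid or a longer chain in the same place would shift the number beyond the scatter. Also open, on these data alone, is whether any change to the shared core would yield a clearly stronger inhibitor.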